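This account rests on a few compounds, and the source may have more. Where it says the series, first, only, none or still open, it means among the compounds named here.

Measured compounds in an ADME assay on HepG2 cells (Homo sapiens) for cytotoxicity, read by MTT assay, with a stated time of 48 h; on this read-out lower numbers stand for higher toxicity in this test and higher numbers for lower toxicity in this test:
- compound 1 `CCS(=O)(=O)Nc1ccc2c(c1)/C(=C/Nc1ccc(CN3CCCCC3)cc1)C(=O)N2`: 5 uM
- compound 2 `CC/C(Nc1ccc(CN2CCCCC2)cc1)=C1/C(=O)Nc2ccc(NS(=O)(=O)CC)cc21`: > 6 uM
- compound 3 `CCS(=O)(=O)Nc1ccc2c(c1)/C(=C(/Nc1ccccc1)c1ccccc1)C(=O)N2`: 4.7 uM

In this assay compound 3 gives 4.7 uM. Compound 1 gives 5 uM in the same test, and the gap between compound 3 and compound 1 lies within the usual scatter of repeated measurements, so the two cannot be told apart on these numbers. Compound 2 returns only a limit, > 6 uM, and not a number; it is one of the values that sit at the boundary described by the limit of > 6 uM in this assay, at which 1 of the 3 values shown sits. Compound 3 thus stands with compound 1 among the two numbers that were read, with compound 2 left open at its limit.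

Compound 4 `CCS(=O)(=O)Nc1ccc2c(c1)/C(=C(/Nc1ccc(N3CCCCC3)cc1)c1ccccc1)C(=O)N2` has not yet been measured. It differs from compound 3 in one place: piperidin-1-yl in place of hydrogen on an aromatic carbon. For the measured compounds named here, no pair of measured compounds differing in a single place is available, so no measured step guides the size of this change. The numbers read for compound 1 and compound 3, which share the ethylsulfonylamino core and the anilino group yet carry different substitution, fall within the scatter of each other, which suggests that substitution on the aniline ring does not move the read-out much here.

Compound 4 is therefore expected to give about 4.5 uM, between 2.2 uM and 9 uM, in this assay; the expected step of a 1.0-fold lower number from compound 3 to compound 4 (0.02 log units; within the scatter) is estimated to stay within the scatter, with no direction beyond it.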

Compound 4, half-maximal toxic concentration: > 6 uM
Compound 4 gave a limit, no number; the forecaster's own chance of this, stated with the estimate: 25%; middle value at least 1.3-fold (0.12 log units) away from the limit.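

Compound 4 returns only a limit and not a number, so in this assay piperidin-1-yl in place of hydrogen on an aromatic carbon, para to a large group, reads as an at least 1.2-fold higher number from compound 3 to compound 4 (0.10 log units; that floor lies within the scatter). For the compounds shown here, this is the first change that can be read at a single place, and it shows that going from phenyl to 4-(piperidin-1-yl)phenyl brings no lower number in this test, though the floor of the step does not by itself separate the two compounds. The upper end of the read-out now restricts what can be learned from this series, with compound 4 sitting at the same limit as compound 2: the limit of > 6 uM in this assay, at which 2 of the 4 values shown sit.

On these data alone, it remains open whether a dimethylamino group or a morpholine ring on the same aromatic carbon would read like piperidin-1-yl, or whether a carboxylic acid there would give a different result. Also open, as far as these compounds go, is the actual number for compound 4, and with it the true size of this step.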